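Changing the amide side chain of compound 3

The source may report more compounds than this note shows. Statements on the series, on what has been measured and on what is new or still open speak of the compounds shown alone.

Three amides built on one shared core have been tested in a functional assay on MCF7 cells (Homo sapiens) for antiproliferative activity, read by MTT assay, with a stated time of 24 h; a lower number here means a stronger inhibitor, a higher number a weaker inhibitor. Compound 1 `CCn1c(C(=O)NCCN)ccc1C(CC)(CC)c1ccc(OCS(=O)(=O)c2ccccc2)c(C)c1` gives 6470 nM, and compound 2 `CCn1c(C(=O)N[C@H](C)CO)ccc1C(CC)(CC)c1ccc(OCS(=O)(=O)c2ccccc2)c(C)c1` gives 10600 nM. The measured step between these two is a 1.6-fold higher number from compound 1 to compound 2 (0.21 log units; within the scatter). Compound 3 `CCn1c(C(=O)N[C@@H](CO)CCCO)ccc1C(CC)(CC)c1ccc(OCS(=O)(=O)c2ccccc2)c(C)c1` gives 29600 nM, the highest number of the three, which makes it the weakest inhibitor in this small set. Two steps lead up to it: a 2.8-fold higher number from compound 2 to compound 3 (0.45 log units; beyond the scatter), and a 4.6-fold higher number from compound 1 to compound 3 (0.66 log units; beyond the scatter).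

Compound 4 `CCn1c(C(=O)N[C@H](C(=O)O)C(C)C)ccc1C(CC)(CC)c1ccc(OCS(=O)(=O)c2ccccc2)c(C)c1` keeps the shared core and differs only on the amide-type nitrogen: a group of 7 heavy atoms (5 carbon, 2 oxygen; no ring) in place of a group of 7 heavy atoms (5 carbon, 2 oxygen; no ring), on an amide-type nitrogen. Among the compounds with values here, the group that enters is 1-carboxy-2-methylpropyl, which none of the three measured compounds carries, so no measured step tests it directly. All three steps are changes on this same nitrogen, however, and the largest of them, a 4.6-fold higher number from compound 1 to compound 3 (0.66 log units; beyond the scatter), is only modest. On that evidence, no step beyond the scatter is expected in this assay, in either direction. The estimated step is a 1.3-fold lower number from compound 3 to compound 4 (0.13 log units; within the scatter). Compound 4 is expected at about 22000 nM, with an estimated range from 8000 nM to 60000 nM.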

Compound 4, half-maximal inhibitory concentration: 24500 nM
The estimate for compound 4 lay 1.1-fold (0.05 log units) below the measured number; low and high end bracket the measured number.
By their numbers in this assay, from the lowest: compounds 1 and 2 (each within the scatter of the next); then compounds 4 and 3 (each within the scatter of the next).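

In this assay, putting 1-carboxy-2-methylpropyl on the amide-type nitrogen in place of the group carried by compound 3 gives a 1.2-fold lower number from compound 3 to compound 4 (0.08 log units; within the scatter) and so shows that this position can take two quite different side chains of the same heavy-atom count with no change that can be told from scatter. Within the data shown here, the same change measured against the two other amides gives a 2.3-fold higher number from compound 2 to compound 4 (0.36 log units; beyond the scatter) and a 3.8-fold higher number from compound 1 to compound 4 (0.58 log units; beyond the scatter) and these modest steps place compound 4 with compound 3, so the four amides now form two pairs, with compounds 1 and 2 on the lower side and compounds 3 and 4 on the higher side, and no compound goes against this split. No measurement is available that would explain why the side chains divide in this way.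

The compounds shown leave open whether a benzyl group or a longer chain such as 3-aminopropyl on this nitrogen would stay within these two pairs or move outside them. They also leave open how the opposite stereocentre in 1-carboxy-2-methylpropyl would read in this assay.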